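Swapping the aryl ketone end of a quinoline chalcone

The source may hold more compounds than are shown below. What is called first, only, known or untested is meant among the compounds shown, and "the series" means these compounds.

Of the compounds shown here, three sharing one core have been measured in a functional assay on MCF7 cells (Homo sapiens) for antiproliferative activity, read by XTT assay, with a stated time of 72 h; a higher number here means a weaker inhibitor, a lower number a stronger inhibitor. Compound 1, `COc1ccc(-c2cc3ccccc3nc2/C=C/C(=O)c2ccc(F)cc2)cc1`, gives 5450 nM. Compound 2, `COc1ccc(C(=O)/C=C/c2nc3ccccc3cc2-c2ccc(OC)cc2)cc1`, gives 7380 nM, and compound 3, `COc1ccc(-c2cc3ccccc3nc2/C=C/C(=O)c2ccco2)cc1`, gives 710 nM. Compound 1 therefore stands second highest of the three numbers: the step of a 1.4-fold higher number from compound 1 to compound 2 (0.13 log units; within the scatter) keeps it level with compound 2, while the step of a 7.7-fold lower number from compound 1 to compound 3 (0.89 log units; beyond the scatter) sets compound 3 clearly apart as the stronger inhibitor. The step of a 10-fold lower number from compound 2 to compound 3 (1.02 log units; beyond the scatter) points the same way.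

Compound 4, `COc1ccc(-c2cc3ccccc3nc2/C=C/C(=O)c2cccs2)cc1`, is not yet measured. Compared with compound 1 the change is thiophen-2-yl in place of 4-fluorophenyl on a carbonyl carbon. The closest guide is the step from compound 1 to compound 3, where furan-2-yl replaced the same 4-fluorophenyl on the same carbonyl carbon and the number fell well beyond the scatter. Since thiophen-2-yl, like furan-2-yl, is a five-membered aromatic ring with one hetero atom entering in place of a six-membered carbon ring, a lower number is expected for compound 4, though its exact size is uncertain and I allow for it being smaller than the step seen with furan-2-yl. I estimate the step of a 4.5-fold lower number from compound 1 to compound 4 (0.66 log units; beyond the scatter). For compound 4 this means an expected value of 1200 nM, with a range from 450 nM to 3500 nM.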

Compound 4, half-maximal inhibitory concentration: 1030 nM
For compound 4 the middle estimate is 1.2-fold (0.07 log units) above the measured one; the measured number falls inside the stated range.
By their numbers in this assay, from the lowest: compounds 3 and 4 (each within the scatter of the next); then compounds 1 and 2 (each within the scatter of the next).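

Thiophen-2-yl on the carbonyl carbon shows that the gain seen with furan-2-yl is not unique to that ring: in this assay, the sulfur-containing ring also stands clear of both six-membered rings (a 5.3-fold lower number from compound 1 to compound 4 (0.72 log units; beyond the scatter); a 7.2-fold lower number from compound 2 to compound 4 (0.86 log units; beyond the scatter)), so among these four compounds, both five-membered rings give lower numbers than both six-membered rings, and none goes against this pattern. Exchanging the ring's oxygen for sulfur makes no difference that can be read here (a 1.5-fold higher number from compound 3 to compound 4 (0.16 log units; within the scatter)), so this assay does not separate furan-2-yl from thiophen-2-yl at this position. Nothing measured here explains why the five-membered rings give the lower numbers.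

On these data alone, all four groups on the carbonyl carbon are aromatic rings, so it remains open whether a ring containing nitrogen, such as pyrrol-2-yl or pyridin-2-yl, would match furan-2-yl and thiophen-2-yl, or whether a non-aromatic group, such as cyclopentyl or methyl, would give a number closer to those of compound 1 and compound 2. It is also unknown whether the same ordering would hold if the 4-methoxyphenyl group on the shared core were replaced by another group, such as an unsubstituted phenyl.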